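A few compounds are considered here, and "the series" means these few. Any claim that something is new, unique, unknown or untested is made for them only; others in the source may bear on it.

Compound 1 `CN(C[C@H]1Cc2ncccc2CN1)[C@H]1CCCc2cccnc21` gives 1300 nm/s in an ADME assay for permeability, using PAMPA, with a stated time of 4 h, at pH 7.4; a lower number here means that the compound crosses the layer more slowly, a higher number that the compound crosses the layer faster.
Compound 2 `NC/C=C\CN(C[C@H]1Cc2ncccc2CN1)[C@H]1CCCc2cccnc21` gives 68 nm/s.
Compound 3 `NC(=O)NC/C=C/CN(C[C@H]1Cc2ncccc2CN1)[C@H]1CCCc2cccnc21` gives 2 nm/s.

Among these three, compound 1 stands highest: compound 2 comes nearest and compound 3 furthest, both well beyond the scatter. Compound 4 `c1cnc2c(c1)CN[C@@H](CN(CCCCNC1CCOCC1)[C@H]1CCCc3cccnc31)C2` is built from compound 1 by one change: 3-((oxan-4-yl)amino)propyl in place of hydrogen on a saturated chain carbon bound to an amine nitrogen. Going by the values given here, two measured steps bear on this, both adding a chain at the same place on compound 1 and both lowering the number sharply: a 19-fold lower number from compound 1 to compound 2 (1.28 log units; beyond the scatter) and a 650-fold lower number from compound 1 to compound 3 (2.81 log units; beyond the scatter). A lowering is therefore expected for compound 4, and the step is estimated as an 8.7-fold lower number from compound 1 to compound 4 (0.94 log units; beyond the scatter). Compound 4 is expected to give 150 nm/s, in a range from 40 nm/s to 500 nm/s.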

Compound 4, apparent permeability: 8 nm/s
Compound 4: middle estimate off by 19-fold (1.27 log units), on the high side; the whole stated range lies above it.
By their numbers in this assay, from the lowest: compound 3; then compound 4; then compound 2; then compound 1.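

In this assay, the 3-((oxan-4-yl)amino)propyl chain again lowers the number at this place, with a 160-fold lower number from compound 1 to compound 4 (2.21 log units; beyond the scatter), so all three chains on this saturated chain carbon bound to an amine nitrogen fall well under compound 1. This chain lands between the two earlier ones, with an 8.5-fold lower number from compound 2 to compound 4 (0.93 log units; beyond the scatter) and a 4.0-fold higher number from compound 3 to compound 4 (0.60 log units; beyond the scatter). Nothing measured here explains this order.

Going by these compounds, it remains open how a shorter chain, a hydroxyl-ended chain or a carboxylic acid would fare at this place. The compounds shown also do not separate the oxane ring from the chain's amine nitrogen.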